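A few compounds are considered here, and "the series" means these few. Any claim that something is new, unique, unknown or untested is made for them only; others in the source may bear on it.

Among the measured compounds shown here, the three compounds measured so far share one core and differ only in the ring that hangs from it. For the measured compounds named here, compound 1 `Cc1ccc(-c2ccnc(C(=O)Nc3ccc(Oc4ccnc5[nH]ccc45)cc3)n2)cc1` is the first of them; in a functional assay on A549 cells (Homo sapiens) for cytotoxicity, read by MTT assay, with a stated time of 72 h (on this read-out lower numbers stand for stronger inhibition and higher numbers for weaker inhibition), compound 1 gives 2380 nM. Compound 2 `O=C(Nc1ccc(Oc2ccnc3[nH]ccc23)cc1)c1nccc(-c2ccc(F)cc2)n1` is reported in this assay as "not active" (no number reported), with no single number attached. Compound 3 `O=C(Nc1ccc(Oc2ccnc3[nH]ccc23)cc1)c1cc(-c2ccc(F)cc2)ncn1` gives 13000 nM in this assay. Of the two entries with numbers, compound 3 holds the higher one, and its distance from compound 1 lies beyond the usual scatter of such measurements, so compound 3 counts as the weaker of the two numbered compounds in this assay.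

Compound 4 `O=C(Nc1ccc(Oc2ccnc3[nH]ccc23)cc1)c1cc(-c2ccccc2)ncn1` differs from compound 3 in one place only: hydrogen in place of fluoro on an aromatic carbon. Going by the values given here, no comparable step between two measured compounds is available, so the expectation rests on compound 3 alone. Exchanging a single fluoro for hydrogen on that ring is expected to shift the number by little, in no fixed direction and within the scatter, which is what the expected step of a 1.2-fold higher number from compound 3 to compound 4 (0.06 log units; within the scatter) means. Compound 4 is accordingly estimated at 15000 nM, with a likely range from 5000 nM to 45000 nM.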

Compound 4, half-maximal inhibitory concentration: 140 nM
The estimate for compound 4 lay 110-fold (2.03 log units) above the measured number, and the stated range ends above it.
By their numbers in this assay, from the lowest: compound 4; then compound 1; then compound 3.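

At this position, on an aromatic carbon para to a large group, a single atom matters a great deal: in this assay the change from 4-fluorophenyl to phenyl gives a 93-fold lower number from compound 3 to compound 4 (1.97 log units; beyond the scatter) and so lies far beyond the scatter. Among the compounds shown here, the earlier compounds offered no step that changed only one place, so this is the first direct sign that the position responds strongly to what it carries. Nothing at hand accounts for the size of this step.

On these data alone, it remains open whether fluoro alone raises the number this much, or whether an amine, a methoxy group or a chlorine in the same place would do the same. Also open, as far as these compounds go, is whether hydrogen in place of fluoro would have a similar effect on the core of compound 2.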